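Lengthening the Linker on a Nucleotide-Based Compound in a Hexokinase-1 Inhibition Assay

The source may report more compounds than this note shows. Statements on the series, on what has been measured and on what is new or still open speak of the compounds shown alone.

Measured compounds:
- compound 1, `O=C(CI)NCCCCCCCNc1ncnc2c1ncn2[C@@H]1O[C@H](COP(=O)(O)OP(=O)(O)OP(=O)(O)O)[C@@H](O)[C@H]1O`: 20%
- compound 2, `Nc1ncnc2c1nc(NCCCCCCNC(=O)CI)n2[C@@H]1O[C@H](COP(=O)(O)OP(=O)(O)OP(=O)(O)O)[C@@H](O)[C@H]1O`: 0%
- compound 3, `CN(CCCN(C)C(=O)CCCNc1ncnc2c1ncn2[C@@H]1O[C@H](COP(=O)(O)OP(=O)(O)OP(=O)(O)O)[C@@H](O)[C@H]1O)C(=O)CCCNC(=O)CI`: 0%

Of the compounds shown here, three have been tested in an assay on isolated protein for inhibition of hexokinase-1 (Rattus norvegicus), with a stated time of 6 h, tested at 10 mM; a higher number here means more inhibition at the concentration tested (going by the name of the read-out), a lower number less inhibition. Compound 1 gives 20%, the highest of the three numbers. Compound 2 gives 0%, and compound 3 gives 0%; each of these lies beyond the usual scatter below compound 1. Among the measured compounds shown here, all three share the same triphosphate-bearing nucleotide core and carry an iodoacetamide arm on a chain, but no two of them differ in only one place, so no single step between measured compounds can be isolated.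

Compound 4, `O=C(I)NCC(=O)NCCCCCCNc1ncnc2c1ncn2[C@@H]1O[C@H](COP(=O)(O)OP(=O)(O)OP(=O)(O)O)[C@@H](O)[C@H]1O`, has not yet been measured. It differs from compound 1 in one place: a group of 8 heavy atoms (3 carbon, 2 nitrogen, 2 oxygen, 1 iodine; no ring) in place of a group of 6 heavy atoms (3 carbon, 1 nitrogen, 1 oxygen, 1 iodine; no ring), on a saturated chain carbon, six bonds along the chain from a nitrogen on an aromatic ring. For the measured compounds named here, the measured set offers no example of this kind of change, so the only guide is that compound 1 stands highest while its two companions sit at the floor of the read-out. The step from compound 1 to compound 4 is therefore expected to be small, if anything a modest drop, and not beyond the scatter.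

Compound 4 is expected to give 10% in this assay, with a range from 0% to 30%. This expected step, a number 10 percentage points lower from compound 1 to compound 4 (within the scatter), would remain within the usual scatter of repeated measurements.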

Compound 4, a percentage reported as inhibition, at one concentration (the size of the read-out at that concentration, not a potency): 0%
Beside the measured number, compound 4's estimate is 10 percentage points above it, within the range that was stated.
By their numbers in this assay, from the lowest: compounds 2, 3 and 4 (each within the scatter of the next); then compound 1.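

In this assay, among the compounds shown here, the exchange on a saturated chain carbon, six bonds along the chain from a nitrogen on an aromatic ring, gives a number 20 percentage points lower from compound 1 to compound 4 (beyond the scatter) and is the first change in the set that can be read at one place alone. It shows that the modest inhibition of compound 1 does not survive when the (((iodomethyl)carbonyl)amino)methyl group gives way to a larger group with one more nitrogen, one more oxygen and one more hydrogen-bond donor, since compound 4 gives 0% in this assay while the rest of the molecule stays the same. Nothing available explains why this exchange lowers the number, so the result records an outcome at this position and not a mechanism.

This single step cannot show which part of the entering group matters, or whether any other group at this position would keep the inhibition of compound 1. A longer chain ending in the same (((iodomethyl)carbonyl)amino) group, or a simple amine or carboxylic acid at the chain end, would help to separate the effect of chain length from that of the reactive end.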